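The source may hold more compounds than are shown below. What is called first, only, known or untested is meant among the compounds shown, and "the series" means these compounds.

Measured compounds:
compound 1 `O=C(/C=C/c1ccc(Cl)cc1)c1ccc[nH]1` gives 18000 nM;
compound 2 `O=C(/C=C/c1ccc(Br)cc1)c1ccc[nH]1` gives 44000 nM;
compound 3 `O=C(/C=C/c1ccc(Cl)cc1)c1ccco1` gives 29000 nM.

All three were tested in a functional assay on PC-3 cells (Homo sapiens) for inhibition, read by MTT assay, with a stated time of 48 h; on this read-out higher numbers stand for weaker inhibition and lower numbers for stronger inhibition. Compound 3 stands second highest of the three numbers; its nearest neighbour is compound 2, and its step to compound 1, a 1.6-fold higher number from compound 1 to compound 3 (0.21 log units; within the scatter), lies within the scatter, so compound 3 and compound 1 cannot be ordered on these numbers. For the measured compounds named here, the one step that is beyond the scatter, a 2.4-fold higher number from compound 1 to compound 2 (0.39 log units; beyond the scatter), is a modest one and concerns bromo in place of chloro on an aromatic carbon.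

Compound 4 `CN(C)c1ccc(/C=C/C(=O)c2ccco2)cc1` differs from compound 3 by dimethylamino in place of chloro on an aromatic carbon. Going by the values given here, neither measured step touches a dimethylamino group, so no measured step bears directly on this change; the nearest comparison is that swapping one group for another on the same aromatic carbon, from compound 1 to compound 2, moved the number only modestly. The expectation is therefore a step of a 1.9-fold lower number from compound 3 to compound 4 (0.29 log units; within the scatter) that is small relative to the wide range allowed. Compound 4 is estimated at 15000 nM, between 4000 nM and 60000 nM.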

Compound 4, half-maximal inhibitory concentration: 13000 nM
For compound 4 the middle estimate is 1.2-fold (0.06 log units) above the measured one; the measured number falls inside the stated range.
By their numbers in this assay, from the lowest: compounds 4, 1, 3 and 2 (each within the scatter of the next, the first and the last beyond it).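

In this assay, the step of a 2.2-fold lower number from compound 3 to compound 4 (0.35 log units; beyond the scatter) is modest but beyond the scatter, and it shows that replacing chloro at this position, on an aromatic carbon para to a group of 9 heavy atoms, can lower the number as well as raise it. The earlier step at this position, a 2.4-fold higher number from compound 1 to compound 2 (0.39 log units; beyond the scatter), went the other way, though it was measured with 1H-pyrrol-2-yl rather than furan-2-yl on the carbonyl carbon. No measurement shown gives a cause for the new step.

The compounds shown leave open whether dimethylamino would give a similar step with 1H-pyrrol-2-yl on the carbonyl carbon. They also leave open how a primary amine, a methoxy group or a diethylamino group would compare with dimethylamino at this position.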